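Swapping the ether substituent on a shared core

The source may report more compounds than this note shows. Statements on the series, on what has been measured and on what is new or still open speak of the compounds shown alone.

Of the compounds shown here, three built on the same core have been measured in an assay on cells for binding affinity to Neuropeptide Y receptor type 1 (Homo sapiens); on this read-out lower numbers stand for stronger inhibition and higher numbers for weaker inhibition. Compound 1 `CCc1sc(CCc2cc(OC)cc(NCc3cc(Cl)cc(NC(=O)OC(C)C)c3)n2)nc1C` carries a methoxy group on the aromatic ring and gives 234 nM. Compound 2 `CCOc1cc(CCc2nc(C)c(CC)s2)nc(NCc2cc(Cl)cc(NC(=O)OC(C)C)c2)c1` gives 33 nM, and compound 3 `CCc1sc(CCc2cc(OCC3(C)CC3)cc(NCc3cc(Cl)cc(NC(=O)OC(C)C)c3)n2)nc1C` gives 17 nM. Compound 3 stands lowest of the three, though its gap to compound 2 lies within the scatter, so the two cannot be ordered; its gap to compound 1 is clear.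

Compound 4 `CCc1sc(CCc2cc(OC3CCCCC3)cc(NCc3cc(Cl)cc(NC(=O)OC(C)C)c3)n2)nc1C` changes the group on the ether oxygen: cyclohexyl in place of (1-methylcyclopropyl)methyl on an oxygen on an aromatic ring. The measured steps that bear on this all enlarge the group on that oxygen: a 7.1-fold lower number from compound 1 to compound 2 (0.85 log units; beyond the scatter), a 14-fold lower number from compound 1 to compound 3 (1.14 log units; beyond the scatter), and a 1.9-fold lower number from compound 2 to compound 3 (0.29 log units; within the scatter). Going from methyl to a larger branched group gave only a small gain, so further enlargement is expected to change little, with the step of a 1.1-fold lower number from compound 3 to compound 4 (0.05 log units; within the scatter) expected to stay near the scatter. Compound 4 is therefore estimated at 15 nM, within a range from 5 nM to 50 nM.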

Compound 4, half-maximal inhibitory concentration: 29 nM
Beside the measured number, compound 4's estimate is 1.9-fold (0.29 log units) below it; low and high end bracket the measured number.
By their numbers in this assay, from the lowest: compounds 3, 4 and 2 (each within the scatter of the next); then compound 1.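

Cyclohexyl sits directly on the ether oxygen, yet this changes little: a 1.7-fold higher number from compound 3 to compound 4 (0.23 log units; within the scatter) and a 1.1-fold lower number from compound 2 to compound 4 (0.06 log units; within the scatter), so neither step separates these compounds. The difference from the methoxy group remains, with an 8.1-fold lower number from compound 1 to compound 4 (0.91 log units; beyond the scatter). Among these four compounds, then, ethyl, (1-methylcyclopropyl)methyl and cyclohexyl on this oxygen all stand apart from methyl but cannot be told from one another, and nothing available explains this.

Going by these compounds, it remains open whether this level holds for a group carrying a further oxygen or nitrogen, such as a 2-methoxyethyl chain or a piperidine ring. Also open, on these data alone, is whether an aromatic group such as benzyl, or a longer chain such as n-hexyl, would give a number in the same range.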